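The source may report more compounds than this note shows. Statements on the series, on what has been measured and on what is new or still open speak of the compounds shown alone.

In a functional assay on MGC-803 cells (Homo sapiens) for inhibition, read by sulforhodamine B assay (a lower number here means a stronger inhibitor, a higher number a weaker inhibitor), compound 1 `CCCc1ccc(NC2=CC(=O)c3nc4n(c3C2=O)[C@H]2OC[C@@H](O)[C@H]2OC4)cc1` gives 1560 nM. Compound 2 `O=C1C(Nc2ccccc2F)=CC(=O)c2c1nc1n2[C@H]2OC[C@@H](O)[C@H]2OC1` gives 2000 nM and compound 3 `O=C1C(Nc2ccc(Br)cc2)=CC(=O)c2c1nc1n2[C@H]2OC[C@@H](O)[C@H]2OC1` gives 2020 nM, so all three lie within the scatter of one another and compound 1 has no real separation from either.

The change to compound 4 `O=C1C=C(Nc2ccccc2F)C(=O)c2c1nc1n2[C@H]2OC[C@@H](O)[C@H]2OC1` is 2-fluorophenyl in place of 4-propylphenyl on an amine nitrogen.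

Going by the values given here, the only measured step at that kind of nitrogen is a 1.0-fold higher number from compound 2 to compound 3 (0.00 log units; within the scatter), which stays within the scatter. Compound 4 shares its 2-fluorophenyl with compound 2, which gives 2000 nM, but the two are isomers and not the same structure, so that value is a guide only. Among the compounds with values here, no measured pair yet shows what such an isomer change does, which calls for a wide range. No step beyond the scatter is expected in this assay, and the expected step is a 1.3-fold higher number from compound 1 to compound 4 (0.11 log units; within the scatter). Compound 4 is estimated at 2000 nM, with an expected range of 800 nM to 5000 nM.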

Compound 4, half-maximal inhibitory concentration: 2080 nM
The estimate for compound 4 lay 1.0-fold (0.02 log units) below the measured number, and the stated range covers the measured number.
By their numbers in this assay, from the lowest: compounds 1, 2, 3 and 4 (each within the scatter of the next).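

In this assay the exchange of 4-propylphenyl for 2-fluorophenyl on an amine nitrogen gives a 1.3-fold higher number from compound 1 to compound 4 (0.12 log units; within the scatter) and so, with 7 heavy atoms entering for 9 leaving, the propyl-bearing and fluorine-bearing phenyl groups cannot be told apart at this nitrogen. The isomer compound 2 carries the same 2-fluorophenyl on the other arrangement of the shared core and gives 2000 nM while compound 4 gives 2080 nM and these two values alone offer no sign that the arrangement matters. No evidence is available to explain this flat response.

Every substituent shown on the amine nitrogen is a phenyl group, so the effect of a non-aromatic group such as cyclohexyl remains open. Also open, as far as these compounds go, is whether a carboxylic acid or dimethylamino group on the phenyl ring, or a chain longer than propyl, would produce a step beyond the scatter.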